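A Pyridine Replaces the Furan on the Shared Core

A few compounds are considered here, and "the series" means these few. Any claim that something is new, unique, unknown or untested is made for them only; others in the source may bear on it.

Compound 1, `Oc1ccc(-c2cc(-c3ccco3)cc(-c3ccccc3O)n2)cc1`: in a functional assay on DU-145 cells (Homo sapiens) for cytotoxicity, read by CCK-8 assay (on this read-out higher numbers stand for weaker inhibition and lower numbers for stronger inhibition), compound 1 shows > 50000 nM, a limit of the assay rather than a number.
Compound 2, `Oc1ccc(-c2cc(-c3ccoc3)cc(-c3ccccc3O)n2)cc1`: in this assay compound 2 gives 28000 nM.

Within the data shown here, compound 2 is the only member of this pair with a numerical value; the other value is a limit, as the limit of > 50000 nM in this assay, at which 1 of the 2 values shown sits, records. Among the measured compounds shown here, the one measured step, an at least 1.7-fold lower number from compound 1 to compound 2 (0.25 log units; that floor lies within the scatter), rests on that limit and carries no clear direction of its own.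

Compound 3, `Oc1ccc(-c2cc(-c3ccccn3)cc(-c3ccccc3O)n2)cc1`, differs from compound 2 by pyridin-2-yl in place of furan-3-yl on an aromatic carbon. For the measured compounds named here, no measured step exchanges a five-membered ring for a six-membered one, so the only guidance is the furan isomer step, which is small and uncertain. Compound 3 is therefore expected to sit close to compound 2, with the estimated step of a 1.1-fold higher number from compound 2 to compound 3 (0.03 log units; within the scatter) giving no change beyond the scatter. For compound 3 the estimated value in this assay is 30000 nM, within the range 10000 nM to 90000 nM, with a real chance that only a limit is reported.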

Compound 3, half-maximal inhibitory concentration: 25400 nM
Estimate against measurement, compound 3: 1.2-fold (0.07 log units) above, and the stated range covers the measured number.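

In this assay, the exchange of furan-3-yl for pyridin-2-yl gives a 1.1-fold lower number from compound 2 to compound 3 (0.04 log units; within the scatter), so at this position, opposite the ring nitrogen, a six-membered aromatic ring with a nitrogen and a five-membered aromatic ring with an oxygen cannot be told apart. Among these compounds, this is the first step at the position that joins two numerical values, and so, unlike the earlier step between the furan isomers, it does not rest on a limit. The other new step, an at least 1.9-fold lower number from compound 1 to compound 3 (0.29 log units; that floor lies within the scatter), does rest on a limit and cannot be read for direction: the limit of > 50000 nM in this assay, at which 1 of the 3 values shown sits.

The compounds shown leave open whether any group at this position would move the number beyond the scatter, for instance an amine, a carboxylic acid, or a pyridin-4-yl ring with its nitrogen placed further out. Among the compounds shown here, they also leave open what the 2-hydroxyphenyl and 4-hydroxyphenyl groups contribute, as both stay the same in all three compounds and no compound carries a methoxy group in place of either hydroxyl.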